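A few compounds are considered here, and "the series" means these few. Any claim that something is new, unique, unknown or untested is made for them only; others in the source may bear on it.

The measured compounds in this set:

- compound 1 `O=C1NC(=S)S/C1=C\C1=Cc2ccccc2OC1` gives 68700 nM
- compound 2 `O=C(O)CN1C(=O)/C(=C/C2=Cc3ccccc3OC2)SC1=S` reaches only a limit of the assay, > 100000 nM
- compound 3 `CC1Oc2ccc(Br)cc2C=C1/C=C1\SC(=S)NC1=O` gives 19900 nM

All three were tested in a functional assay on MCF7 cells (Homo sapiens) for antiproliferative activity, read by MTT assay, with a stated time of 72 h; a higher number here means a weaker inhibitor, a lower number a stronger inhibitor. Compound 1 and compound 3 share the same five-membered ring bearing the amide-type nitrogen, but how their two cores differ is not broken down here. Within the pair that is measured on both sides, the change carboxymethyl in place of hydrogen on an amide-type nitrogen in a ring gave an at least 1.4-fold higher number from compound 1 to compound 2 (0.16 log units; that floor lies within the scatter); the floor of that step lies within the scatter because compound 2 sits at the limit of > 100000 nM in this assay, at which 1 of the 3 values shown sits, so only a lower bound of the step is known. Compound 3 stands at the lowest number of the two numbers given, and the gap to compound 1 is beyond the scatter.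

Compound 4 `CC1Oc2ccc(Br)cc2C=C1/C=C1\SC(=S)N(CC(=O)O)C1=O` has not yet been measured in this assay. It arises from compound 3 by carboxymethyl in place of hydrogen on an amide-type nitrogen in a ring, the same change that turned compound 1 into compound 2, at the same place. From the step of an at least 1.4-fold higher number from compound 1 to compound 2 (0.16 log units; that floor lies within the scatter) the author expects compound 4 to give a higher number than compound 3, estimated as a 3.0-fold higher number from compound 3 to compound 4 (0.48 log units; beyond the scatter), with compound 4 expected near 60000 nM in this assay, between 25000 nM and 150000 nM.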

Compound 4, half-maximal inhibitory concentration: > 50000 nM
Compound 4: only a limit was reported; the forecaster's own chance of this, stated with the estimate: 35%; the middle value does not contradict the limit.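

In this assay compound 4 reaches only a limit of the assay, > 50000 nM, and not a number. Carboxymethyl in place of hydrogen on the amide-type nitrogen therefore gave an at least 2.5-fold higher number from compound 3 to compound 4 (0.40 log units; beyond the scatter), so on the core of compound 3 the change raised the number beyond the scatter, whereas the floor on the core of compound 1 stays within it: the same change on two cores in this assay, an at least 1.4-fold higher number (0.16 log units; that floor lies within the scatter) from compound 1 to compound 2 and an at least 2.5-fold higher number (0.40 log units; beyond the scatter) from compound 3 to compound 4; the limit leaves it open whether they differ Both steps are floors only, so these two pairs do not show how large the change is on either core, and they do not show that it carries over with the same size.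

What the compounds shown leave open is whether another group on that nitrogen, such as a methyl ester, an amine or a longer chain ending in a carboxylic acid, would behave as carboxymethyl does. They also leave open how the change would fare on any core other than these two.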